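The compounds below may be only part of what the source reports. "The series", "measured", "known", "first", "only" and "open" are said of these compounds alone.

Compound 2, `CN1C(=S)[C@@H](NC(=O)c2nc(Cc3ccccc3)n(CCC(F)(F)F)n2)COc2ccccc21`, is a close analogue of compound 1, `COCCn1nc(C(=O)N[C@H]2COc3ccccc3N(C)C2=S)nc1Cc1ccccc1`. In a toxicity assay on HT-29 cells (Homo sapiens) for cytotoxicity (on this read-out lower numbers stand for higher toxicity in this test and higher numbers for lower toxicity in this test), compound 2 gives only a limit of the assay, > 100000 nM. In this assay compound 1 likewise gives only a limit, > 100000 nM. Within the data shown here, the one measured step, a step that the two limits leave unreadable from compound 1 to compound 2, therefore has no readable size, and the limit of > 100000 nM in this assay, at which 2 of the 2 values shown sit, shows that both values rest at the same limit. Compound 3, `CN1C(=S)[C@@H](NC(=O)c2nc(Cc3ccccc3)n(-c3ncccn3)n2)COc2ccccc21`, is still to be measured in this assay. Its change from compound 2 is pyrimidin-2-yl in place of 3,3,3-trifluoropropyl on an aromatic nitrogen. Among the measured compounds shown here, no measured step bears on a change at this aromatic nitrogen in a readable way, so nothing beyond the scatter is expected in this assay. The expected step of a number no higher from compound 2 to compound 3 (the limit leaves the size open) is thus estimated as essentially none. Compound 3 is expected to sit at about 100000 nM in this assay, with a range from 40000 nM to 250000 nM, most likely reported again as a limit rather than a number.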

Compound 3, half-maximal cytotoxic concentration: > 100000 nM
Compound 3 ended at the assay's limit; the forecaster's own chance of this, stated with the estimate: 80%; the middle value sits exactly at the limit.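

In this assay compound 3 gives > 100000 nM, which is a limit of the assay. No step among compound 1, compound 2 and compound 3 can be read: the limit of > 100000 nM in this assay, at which 3 of the 3 values shown sit.

The compounds shown leave open whether any group on the aromatic nitrogen gives a toxicity value readable as a number.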